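From Cyclohexyl Back to an Aryl Amine on the Shared Core

The source may report more compounds than this note shows. Statements on the series, on what has been measured and on what is new or still open speak of the compounds shown alone.

Compound 3 `O=C1C(NC2CCCCC2)=CC(=O)c2c1nc1n2[C@H]2OC[C@@H](O)[C@H]2OC1` stands in a functional assay on ECa-109 cells for inhibition, with ECa-109 cell line (Homo sapiens) as the target, read by sulforhodamine B assay (on this read-out lower numbers stand for stronger inhibition and higher numbers for weaker inhibition), only as a limit, giving > 16000 nM. Compound 2 `O=C1C(NC2CCCC2)=CC(=O)c2c1nc1n2[C@H]2OC[C@@H](O)[C@H]2OC1` likewise reaches only a limit, giving > 16000 nM. Compound 1 `O=C1C(Nc2cccc(Cl)c2)=CC(=O)c2c1nc1n2[C@H]2OC[C@@H](O)[C@H]2OC1` carries a 3-chlorophenyl group on the amine nitrogen, and in this assay compound 1 gives 3080 nM. Compound 4 `O=C1C(Nc2ccc(I)cc2)=CC(=O)c2c1nc1n2[C@H]2OC[C@@H](O)[C@H]2OC1` differs from compound 3 in one place: 4-iodophenyl in place of cyclohexyl on an amine nitrogen. The measured step that bears on it is an at least 5.1-fold higher number from compound 1 to compound 3 (0.71 log units; beyond the scatter), which in reverse direction swaps a cyclohexyl for an aryl group; an at least 5.1-fold higher number from compound 1 to compound 2 (0.71 log units; beyond the scatter) points the same way. For compound 4 a step to a lower number beyond the scatter is therefore expected, an at least 4.5-fold lower number from compound 3 to compound 4 (0.66 log units; beyond the scatter). Compound 4 is estimated at 3500 nM, between 1000 nM and 13000 nM.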

Compound 4, half-maximal inhibitory concentration: 2530 nM
Compound 4: middle estimate off by 1.4-fold (0.14 log units), on the high side; low and high end bracket the measured number.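

In this assay, a second aryl amine with a different halogen at a different ring place also gives a lower number than the cycloalkyl amines (an at least 6.3-fold lower number from compound 3 to compound 4 (0.80 log units; beyond the scatter); an at least 6.3-fold lower number from compound 2 to compound 4 (0.80 log units; beyond the scatter)). Both steps are bounds only, not true sizes: the limit of > 16000 nM in this assay, at which 2 of the 4 values shown sit. Between the two aryl amines, the change from 3-chlorophenyl to 4-iodophenyl stays within the scatter (a 1.2-fold lower number from compound 1 to compound 4 (0.09 log units; within the scatter)), so this swap does not separate them. As far as these compounds go, what a plain phenyl or a benzyl group on the amine nitrogen would give remains open. So does whether the halogen contributes anything beyond the aromatic ring itself.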